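This account rests on a few compounds, and the source may have more. Where it says the series, first, only, none or still open, it means among the compounds named here.

Compound 1 `O=[N+]([O-])c1cccc(CSc2nnc(-c3ccncc3)n2-c2ccccc2)c1` gives 19800 nM in a functional assay on HCT-116 cells (Homo sapiens) for inhibition, read by MTT assay, with a stated time of 48 h; on this read-out higher numbers stand for weaker inhibition and lower numbers for stronger inhibition.
Compound 2 `O=C(CSc1nnc(-c2ccncc2)n1-c1ccccc1)N/N=C/c1ccccc1` gives 14700 nM in this assay.
Compound 3 `COc1ccc(/C=N/NC(=O)CSc2nnc(-c3ccncc3)n2-c2ccccc2)cc1` gives 19200 nM in this assay.

All three numbers lie close together: the number for compound 3 sits within the usual scatter of the number for compound 1 and of the number for compound 2, so none of the three can be told apart as stronger or weaker. Among the measured compounds shown here, the only single change among them, a 1.3-fold higher number from compound 2 to compound 3 (0.12 log units; within the scatter), is too small to count as a real effect.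

Compound 4 `O=C(CSc1nnc(-c2ccncc2)n1-c1ccccc1)N/N=C/c1ccc([N+](=O)[O-])cc1` is the next step from compound 3: nitro in place of methoxy on an aromatic carbon. For the measured compounds named here, no measured pair shows a nitro group entering at this position, and compound 1, which also carries a nitro group, differs from the others in more than one place, so its value alone cannot guide the step. Going by the values given here, the one bearing step, from compound 2 to compound 3, changed the same position without a change beyond the scatter. The expected step is therefore a 1.1-fold lower number from compound 3 to compound 4 (0.03 log units; within the scatter), that is, none beyond the scatter. Compound 4 is estimated at 18000 nM, with a range from 7000 nM to 45000 nM.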

Compound 4, half-maximal inhibitory concentration: 10200 nM
Compound 4: the middle estimate sits 1.8-fold (0.25 log units) above what was measured, and the stated range covers the measured number.
By their numbers in this assay, from the lowest: compounds 4, 2, 3 and 1 (each within the scatter of the next).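

Replacing methoxy with nitro on this ring, the change from 4-methoxyphenyl to 4-nitrophenyl, gives a 1.9-fold lower number from compound 3 to compound 4 (0.27 log units; within the scatter) in this assay, and putting nitro in place of hydrogen gives a 1.4-fold lower number from compound 2 to compound 4 (0.16 log units; within the scatter). This position has now carried hydrogen, methoxy and nitro, and every step among the three stays within the scatter, so none of these groups can be ranked above another in this test. No measurement is at hand that could explain these small differences.

Still open, on these data alone, is whether an amine or a carboxylic acid at this same position would move the number beyond the scatter. Also open, as far as these compounds go, is whether a longer chain on this ring, or a change elsewhere in the shared core, would do more than the groups tried here.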